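Biguanides against bladder cancer cells: swapping the amine end

The source may hold more compounds than are shown below. What is called first, only, known or untested is meant among the compounds shown, and "the series" means these compounds.

Three biguanides, each bearing an aryl group on one end and a small amine on the other, have been tested in a functional assay on UMUC3 cells (Homo sapiens) for antiproliferative activity, read by MTT assay, with a stated time of 72 h; a higher number here means a weaker inhibitor, a lower number a stronger inhibitor. Compound 1 `CCN(C)C(=N)NC(=N)Nc1ccc(C(F)(F)F)cc1` carries a trifluoromethyl-substituted aryl group and an ethyl(methyl)amino group; in this assay compound 1 gives 6900 nM. Compound 2 `CCCCCCCNC(=N)NC(=N)Nc1ccc(F)c(F)c1` has a heptylamino group on a difluorophenyl core, and in this assay compound 2 gives 2100 nM. Compound 3 `CCN(CC)C(=N)NC(=N)Nc1ccc(F)c(F)c1` keeps that difluorophenyl core but bears a diethylamino group; in this assay compound 3 gives 22100 nM.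

Among these three numbers compound 1 stands second highest: its nearest neighbour is compound 3, whose number is higher by a margin beyond the scatter, and compound 2 lies further off with a lower number, again beyond the scatter.

Compound 4 `CC(C)NC(=N)NC(=N)Nc1ccc(C(F)(F)F)cc1` has not been measured. It differs from compound 1 in one place: isopropylamino in place of ethyl(methyl)amino on a carbon with a double bond to nitrogen. Compound 2 and compound 3 show that, on the same difluorophenyl core, the compound with a hydrogen on the amine nitrogen gives the lower number, so a decrease for compound 4 is expected, with a step of a 2.3-fold lower number from compound 1 to compound 4 (0.36 log units; beyond the scatter) beyond the scatter. The estimated value for compound 4 in this assay is 3000 nM, within a range from 1200 nM to 8000 nM.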

Compound 4, half-maximal inhibitory concentration: 5200 nM
Estimate against measurement, compound 4: 1.7-fold (0.24 log units) below; measured number inside the range.
By their numbers in this assay, from the lowest: compound 2; then compounds 4 and 1 (each within the scatter of the next); then compound 3.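

The two compounds contain the same atoms, joined differently at one place, on a carbon with a double bond to nitrogen. Exchanging ethyl(methyl)amino for isopropylamino gives a 1.3-fold lower number from compound 1 to compound 4 (0.12 log units; within the scatter) in this measure of growth inhibition (this assay), so the two compounds cannot be told apart, even though isopropylamino brings a hydrogen-bond donor that ethyl(methyl)amino lacks. The gap seen between compound 2 and compound 3 on their own core therefore does not simply carry over as a rule about a hydrogen on the amine nitrogen, at least not on the core of compound 1. Nothing measured here explains why this exchange leaves the number within the scatter.

The compounds shown leave open whether a longer chain such as octylamino, or a ring such as piperidine, placed at this same position on the core of compound 1 would shift the number beyond the scatter. Also open, from the compounds shown here alone, is whether heptylamino, seen here only on the core of compound 2, would bring the core of compound 1 close to the number seen in this assay, where compound 2 gives 2100 nM.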